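From Methoxy to Nitro on a Shared Core

The source may hold more compounds than are shown below. What is called first, only, known or untested is meant among the compounds shown, and "the series" means these compounds.

Measured in a functional assay on MDA-MB-231 cells (Homo sapiens) for inhibition, read by CCK-8 assay, with a stated time of 72 h, tested at 20 uM; on this read-out lower numbers stand for less inhibition of growth and higher numbers for more inhibition of growth at the one concentration tested:
compound 1 `CC(C)(C)OC(=O)/C=C1/C(=O)Nc2ccccc21`: 87.6%
compound 2 `COc1ccc2c(c1)/C(=C\C(=O)OC(C)(C)C)C(=O)N2`: 87.6%

Among the compounds with values here, compound 2 stands level with compound 1 within the scatter, the only step known, no change at the digits printed from compound 1 to compound 2 (within the scatter), being flat. Compound 3 `CC(C)(C)OC(=O)/C=C1/C(=O)Nc2ccc([N+](=O)[O-])cc21` differs from compound 2 by nitro in place of methoxy on an aromatic carbon. Within the data shown here, no measured step bears on a nitro group here; the one step known, methoxy for hydrogen, shows no change in this assay. Without a step that speaks against it, compound 3 is expected to stay near compound 2, with a number 2.6 percentage points lower from compound 2 to compound 3 (within the scatter), and its estimated value is 85%, between 70% and 95%.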

Compound 3, percent growth inhibition at one concentration: 86.9%
The estimate for compound 3 lay 1.9 percentage points below the measured number; low and high end bracket the measured number.
By their numbers in this assay, from the lowest: compounds 3, 1 and 2 (each within the scatter of the next).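

In this assay, nitro on this aromatic carbon gives a result much like methoxy (a number 0.7 percentage points lower from compound 2 to compound 3 (within the scatter)) and hydrogen (a number 0.7 percentage points lower from compound 1 to compound 3 (within the scatter)). The position has now carried these three groups with no step beyond the scatter, so a larger group with more hydrogen-bond acceptors has not shifted the read-out at this one concentration. The data offer no explanation for this flat result.

On these data alone, whether an amine or a carboxylic acid on this carbon would hold the same level remains open. So does whether the three compounds would stay together at lower concentrations.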